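From 2-nitrophenyl to 4-nitrophenyl in compound 2

The compounds below may be only part of what the source reports. "The series", "measured", "known", "first", "only" and "open" are said of these compounds alone.

Compound 1 `O=C1/C(=C/c2ccccc2)CCC/C1=C\c1ccccc1[N+](=O)[O-]`: 26000 nM
Compound 2 `COc1cc(/C=C2\CCC/C(=C\c3ccccc3[N+](=O)[O-])C2=O)cc(OC)c1OC`: 79000 nM

In an ADME assay on HPLF cells (Homo sapiens) for cytotoxicity, with a stated time of 24 h (a higher number here means that more compound is tolerated, a lower number that less compound is tolerated), compound 1 gives 26000 nM and compound 2 gives 79000 nM, the higher of the two numbers by more than the usual scatter. Compound 3 `COc1cc(/C=C2\CCC/C(=C\c3ccc([N+](=O)[O-])cc3)C2=O)cc(OC)c1OC` has the same atoms as compound 2, joined differently: 4-nitrophenyl in place of 2-nitrophenyl on a double-bonded chain carbon bound to a double-bonded ring carbon. Going by the values given here, no measured pair shows a change of this kind, so the only guide is compound 2 at 79000 nM. A small downward step, within the scatter, is expected: a 1.2-fold lower number from compound 2 to compound 3 (0.08 log units; within the scatter). The estimate for compound 3 is 65000 nM, with an expected range of 25000 nM to 150000 nM.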

Compound 3, half-maximal cytotoxic concentration in the HPLF assay: 378000 nM
For compound 3 the middle estimate is 5.8-fold (0.76 log units) below the measured one, and the stated range ends below it.
By their numbers in the HPLF assay, from the lowest: compound 1; then compound 2; then compound 3.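

In the HPLF assay compound 2 gives 79000 nM and compound 3 gives 378000 nM. Swapping 2-nitrophenyl for 4-nitrophenyl in the HPLF assay gives a 4.8-fold higher number from compound 2 to compound 3 (0.68 log units; beyond the scatter) with no atom gained or lost, so how the same atoms are joined at this place clearly matters to how much compound the cells tolerate. In a physicochemical assay for lipophilicity (on this read-out lower numbers stand for lower lipophilicity and higher numbers for higher lipophilicity), compound 2 gives 4.33 and compound 3 gives 4.56. In the physicochemical assay the same swap gives a number 0.23 log units higher from compound 2 to compound 3 (within the scatter) and so does not separate the two compounds. Nothing shown here gives a reason for the rise in tolerated concentration. Going by these compounds, whether a phenyl carrying an amine or a carboxylic acid would be tolerated as well stays open. So does whether this swap gives a similar step on the core of compound 1.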